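The source may hold more compounds than are shown below. What is called first, only, known or untested is meant among the compounds shown, and "the series" means these compounds.

Compound 1 `Cc1ccccc1NS(=O)(=O)c1ccc(NC(=O)NCCCCl)cc1` and compound 2 `CCc1ccccc1NS(=O)(=O)c1ccc(NC(=O)NCCCCl)cc1` share one core, while compound 3 `CCNC(=O)Nc1ccc(S(=O)(=O)Oc2ccccc2CC)cc1` and the not yet measured compound 4 `CCCc1ccccc1OS(=O)(=O)c1ccc(NC(=O)NCC)cc1` share another; the difference between the two cores is not broken down here. In a functional assay on M21 cells (Homo sapiens) for cytotoxicity, read by sulforhodamine B assay, with a stated time of 48 h (a lower number here means a stronger inhibitor, a higher number a weaker inhibitor), compound 1 gives only a limit, > 200000 nM. Compound 2 likewise gives only a limit in this assay, > 200000 nM. The change between them, (methyl in place of hydrogen on a saturated chain carbon bound to an aromatic carbon), gives a step that the two limits leave unreadable from compound 1 to compound 2 because both values sit at the limit of > 200000 nM in this assay, at which 2 of the 3 values shown sit. Within the data shown here, compound 3 gives 2500 nM in this assay, the only number among the three. Compound 4 differs from compound 3 by the same kind of change, (methyl in place of hydrogen on a saturated chain carbon, two bonds along the chain from an aromatic carbon), though the place is two bonds along the chain from an aromatic carbon rather than bound to it. The earlier step, a step that the two limits leave unreadable from compound 1 to compound 2, offers no readable size, so for compound 4 a small step is expected, no change at the digits printed from compound 3 to compound 4 (within the scatter). Compound 4 is thus estimated at 2500 nM in this assay, between 800 nM and 8000 nM.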

Compound 4, half-maximal inhibitory concentration: 800 nM
Compound 4: the middle estimate sits 3.1-fold (0.49 log units) above what was measured; low and high end bracket the measured number.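

In this assay the added methyl gives a 3.1-fold lower number from compound 3 to compound 4 (0.49 log units; beyond the scatter), a modest but readable step on the core shared by these two compounds. This does not show that the change carries from one core to another, because the step on the other core cannot be read: the limit of > 200000 nM in this assay, at which 2 of the 4 values shown sit. The two changes also differ in place, one on a saturated chain carbon bound to an aromatic carbon, the other two bonds along the chain from an aromatic carbon.

From the compounds shown here alone, whether a chain longer than propyl, or an amine at its end, would lower the number further on the core of compound 3 stays open. No pair shown separates the two cores in one place.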